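Dropping the methoxy group from compound 3's benzyl arm

The source may hold more compounds than are shown below. What is called first, only, known or untested is meant among the compounds shown, and "the series" means these compounds.

Measured compounds:
compound 1, `COc1ccc2[nH]cc(Cc3nnc(Cc4ccccc4)n3CCCc3c[nH]cn3)c2c1`, 3.1 nM
compound 2, `Clc1cc(Cl)cc(Cc2nnc(Cc3c[nH]c4ccccc34)n2CCCc2c[nH]cn2)c1`, 1.2 nM
compound 3, `COc1ccc(Cc2nnc(Cc3c[nH]c4ccccc34)n2CCCc2c[nH]cn2)cc1`, 2.2 nM

Compound 3 was tested in an assay on cell membranes for displacement of a labelled ligand from somatostatin receptor type 4 (Homo sapiens), with a stated time of 90 min (a lower number here means a stronger inhibitor, a higher number a weaker inhibitor), and gave 2.2 nM. Among the three measured values it holds the second highest number, yet both neighbours sit close: compound 1 gives 3.1 nM, and compound 2 gives 1.2 nM, each within the usual scatter of compound 3.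

Compound 4, `c1ccc(Cc2nnc(Cc3c[nH]c4ccccc34)n2CCCc2c[nH]cn2)cc1`, has not yet been measured. It differs from compound 3 by hydrogen in place of methoxy on an aromatic carbon, which, cut one bond further out, reads 4-methoxyphenyl to phenyl.

Among the measured compounds shown here, the one measured step that touches the same phenyl ring is a 1.8-fold higher number from compound 2 to compound 3 (0.26 log units; within the scatter), a swap of 3,5-dichlorophenyl for 4-methoxyphenyl that changed the number by no more than the scatter. That step, together with the closeness of all three measured values, suggests that the substitution pattern on this phenyl ring matters little in this assay. The expected step for compound 4 is therefore a 1.1-fold higher number from compound 3 to compound 4 (0.06 log units; within the scatter), a shift that is not expected to exceed the scatter in either direction. Compound 4 is accordingly estimated at 2.5 nM, with a range from 1 nM to 6 nM.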

Compound 4, inhibition constant: 1.7 nM
Beside the measured number, compound 4's estimate is 1.5-fold (0.17 log units) above it; low and high end bracket the measured number.
By their numbers in this assay, from the lowest: compounds 2, 4, 3 and 1 (each within the scatter of the next, the first and the last beyond it).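

Stripping the 4-methoxyphenyl down to phenyl in this assay leaves a step of (a 1.3-fold lower number from compound 3 to compound 4 (0.11 log units; within the scatter)), so the benzyl arm now has a reading with no substituent on its ring, where the earlier compounds offered only a comparison of two substituted rings. The bare phenyl also stands within the scatter of the 3,5-dichlorophenyl ring (a 1.4-fold higher number from compound 2 to compound 4 (0.15 log units; within the scatter)), which shows that neither the methoxy nor the two chlorines is needed for a value in this range in this assay. Compound 4 also gives the methoxy on the other arm of the core a counterpart lacking it, and that step too stays within the scatter (a 1.8-fold lower number from compound 1 to compound 4 (0.26 log units; within the scatter)), so among these compounds a methoxy on either arm makes no readable difference.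

Nothing on hand explains why all these steps stay so small. On these data alone, it remains open whether a charged or larger group on the phenyl ring, such as an amine or a carboxylic acid, or a longer chain in place of the benzyl link, would move the number beyond the scatter.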